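A Second Methoxy on an Already Weak Pyrazoline

A few compounds are considered here, and "the series" means these few. Any claim that something is new, unique, unknown or untested is made for them only; others in the source may bear on it.

Measured compounds:
Compound 1 `FC(F)(F)c1ccc(C2CC(c3ccccc3)=NN2c2ccc(-c3ccccc3)nn2)cc1`: 9160 nM
Compound 2 `COc1ccc(C2CC(c3ccccc3)=NN2c2ccc(-c3ccccc3)nn2)cc1`: 91700 nM

In a functional assay on A549 cells (Homo sapiens) for antiproliferative activity, read by MTT assay, with a stated time of 24 h (a lower number here means a stronger inhibitor, a higher number a weaker inhibitor), compound 2 gives 91700 nM, the higher of the two numbers; compound 1 sits lower by a 10-fold higher number from compound 1 to compound 2 (1.00 log units; beyond the scatter). Compound 3 `COc1ccc(C2CC(c3ccccc3)=NN2c2ccc(-c3ccccc3)nn2)c(OC)c1` differs from compound 2 by methoxy in place of hydrogen on an aromatic carbon. Among the compounds with values here, no measured step adds a group to a hydrogen; the only step known swaps one group for another on this ring, and it was modest. The step from compound 2 to compound 3 is therefore expected to stay within the scatter, a 1.1-fold higher number from compound 2 to compound 3 (0.04 log units; within the scatter). Compound 3 is estimated at 100000 nM, with a range from 40000 nM to 250000 nM.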

Compound 3, half-maximal inhibitory concentration: 9560 nM
For compound 3 the middle estimate is 10-fold (1.02 log units) above the measured one, outside the stated range (below it).
By their numbers in this assay, from the lowest: compounds 1 and 3 (each within the scatter of the next); then compound 2.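

In this assay, a methoxy on the aromatic carbon ortho to a large group and meta to the first methoxy gives a 9.6-fold lower number from compound 2 to compound 3 (0.98 log units; beyond the scatter), so replacing hydrogen at this position can change the number well beyond the scatter. The 2,4-dimethoxyphenyl group also sits level with 4-(trifluoromethyl)phenyl, with a 1.0-fold higher number from compound 1 to compound 3 (0.02 log units; within the scatter) as the step. No measurement shown here explains the change. On these data alone, whether a hydroxyl or an amine on that same carbon would shift the number as the methoxy does remains open.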